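Swapping a Fluorinated Ring for Thiophene in a Channel Antagonist

The source may hold more compounds than are shown below. What is called first, only, known or untested is meant among the compounds shown, and "the series" means these compounds.

Of the compounds shown here, three sharing one core have been measured in an assay on CHO cells for antagonist activity at transient receptor potential cation channel subfamily V member 1 (Homo sapiens), read by FLIPR; on this read-out higher numbers stand for weaker inhibition and lower numbers for stronger inhibition. Compound 1 `CC(C(=O)NCc1ccc(C(F)(F)F)nc1-c1ccccc1)c1ccc(NS(C)(=O)=O)c(F)c1` gives 6.4 nM. Compound 2 `CC(C(=O)NCc1ccc(C(F)(F)F)nc1-c1ccccc1F)c1ccc(NS(C)(=O)=O)c(F)c1` gives 63.3 nM, the highest of the three numbers; its nearest neighbour is compound 1, and the furthest is compound 3 `CC(C(=O)NCc1ccc(C(F)(F)F)nc1-c1ccc(F)c(Cl)c1)c1ccc(NS(C)(=O)=O)c(F)c1`, which gives 0.2 nM. The step of a 9.9-fold higher number from compound 1 to compound 2 (1.00 log units; beyond the scatter) came with fluoro in place of hydrogen on an aromatic carbon, the step of a 320-fold lower number from compound 2 to compound 3 (2.50 log units; beyond the scatter) with 3-chloro-4-fluorophenyl in place of 2-fluorophenyl on an aromatic carbon, and the step of a 32-fold lower number from compound 1 to compound 3 (1.51 log units; beyond the scatter) sets the same group against plain phenyl.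

Compound 4 `CC(C(=O)NCc1ccc(C(F)(F)F)nc1-c1ccsc1)c1ccc(NS(C)(=O)=O)c(F)c1` has not yet been measured in this assay. Its change from compound 2 is thiophen-3-yl in place of 2-fluorophenyl on an aromatic carbon. The measured steps that bear on this are a 9.9-fold higher number from compound 1 to compound 2 (1.00 log units; beyond the scatter) and a 320-fold lower number from compound 2 to compound 3 (2.50 log units; beyond the scatter), both beyond the scatter and both leaving compound 2 with the highest number, so a move away from 2-fluorophenyl would be expected to lower the number, though none of the three measured rings is a five-membered one. The expected step is therefore a 6.3-fold lower number from compound 2 to compound 4 (0.80 log units; beyond the scatter), a moderate fall rather than the large one seen toward compound 3. Compound 4 is estimated to give 10 nM in this assay, most likely between 2 nM and 50 nM.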

Compound 4, inhibition constant: 2 nM
Estimate against measurement, compound 4: 5.0-fold (0.70 log units) above; measured number inside the range.
By their numbers in this assay, from the lowest: compound 3; then compound 4; then compound 1; then compound 2.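

At this position, next to the ring nitrogen, the aromatic ring need not be six-membered or made of carbon only: in this assay, thiophen-3-yl goes beyond plain phenyl, with a 3.2-fold lower number from compound 1 to compound 4 (0.51 log units; beyond the scatter), and far beyond 2-fluorophenyl, with a 32-fold lower number from compound 2 to compound 4 (1.50 log units; beyond the scatter). It still falls short of the substituted six-membered ring, with a 10-fold higher number from compound 3 to compound 4 (1.00 log units; beyond the scatter), so the four rings now form a clear order: 3-chloro-4-fluorophenyl gives the lowest number, followed by thiophen-3-yl, phenyl and 2-fluorophenyl. No measured property of these rings or compounds is available to explain that order.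

The compounds shown leave open whether the attachment point on the thiophene matters, as a thiophen-2-yl group would test, and whether the sulfur itself counts, as a furan-3-yl group would test. They also leave open whether chloro and fluoro on a thiophene ring would lower the number as far as they do on the phenyl ring of compound 3.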